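Cutting Back the Hydroxylated Chain of Compound 3

The source may hold more compounds than are shown below. What is called first, only, known or untested is meant among the compounds shown, and "the series" means these compounds.

Three compounds come first. Compound 1 (`O=C(OCCO)OCCc1ccc(OCc2ccccc2)c(OCc2ccccc2)c1`) has the entry "not determined" (no result reported) in an ADME assay on MRC5 cells (Homo sapiens) for inhibition, read by MTT assay, with a stated time of 72 h; on this read-out higher numbers stand for weaker inhibition and lower numbers for stronger inhibition. Compound 2 (`O=C(OCCO)OCCc1ccc(O)c(O)c1`) stands the same way in this assay, with "not determined" (no result reported). Compound 3 (`O=C(OCCCCCCCCO)OCCc1ccc(O)c(O)c1`) gives only a limit in this assay, > 50000 nM, and not a number. Among the measured compounds shown here, compound 3 therefore holds the single reading of the three, and that reading is a limit.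

Compound 4 (`CCCCCCOC(=O)OCCc1ccc(O)c(O)c1`) departs from compound 3 by one change, (hydrogen in place of 2-hydroxyethyl on a saturated chain carbon, six bonds along the chain from an oxygen next to a carbonyl group). Hydrogen takes the place of 2-hydroxyethyl on a saturated chain carbon, six bonds along the chain from an oxygen next to a carbonyl group.

For the measured compounds named here, the only guide is compound 3, whose limit is > 50000 nM. Going by the values given here, no measured pair shows what such a change does in this assay, so no shift beyond the scatter is expected. The expected step is a step that the limit leaves unreadable from compound 3 to compound 4. The estimated value for compound 4 is 55000 nM, with an expected range of 20000 nM to 100000 nM.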

Compound 4, half-maximal inhibitory concentration: 11200 nM
Compound 4: middle estimate off by 4.9-fold (0.69 log units), on the high side; the measured number lies below the stated range.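

In this assay, the change gives the series its first step that can be sized: hydrogen in place of 2-hydroxyethyl on the saturated chain carbon gives an at least 4.4-fold lower number from compound 3 to compound 4 (0.64 log units; beyond the scatter). This step lies beyond the scatter, so the hydroxylated chain end of compound 3 is not a silent feature here, and its removal goes with stronger inhibition on this read-out. On these data alone, the true size of the step remains unknown because compound 3 gives only a limit: the limit of > 50000 nM in this assay, at which 1 of the 4 values shown sits.

This single change removes the hydroxyl and shortens the chain together, so the two cannot be told apart from these compounds. As far as these compounds go, whether an amine or a carboxylic acid on that same saturated chain carbon, or a longer chain, would move the number further also stays open.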